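Chloro in Place of Hydroxycarbamoyl on the Shared Core

The source may hold more compounds than are shown below. What is called first, only, known or untested is meant among the compounds shown, and "the series" means these compounds.

Compound 1 `CCOc1ccc(Br)cc1-c1cc(Nc2ccc(C(=O)NO)cc2)nc(N)n1` was tested in an assay on Sf9 cells for inhibition of 1-acyl-sn-glycerol-3-phosphate acyltransferase beta (Homo sapiens) (on this read-out lower numbers stand for stronger inhibition and higher numbers for weaker inhibition), where compound 1 gives 88 nM. Among the three measured compounds it stands second highest: compound 3 `Cc1ccc(Cl)cc1-c1cc(Nc2ccc(C(F)(F)F)cc2)nc(N)n1` gives 140 nM, within the scatter of compound 1, while compound 2 `Cc1ccc(Cl)cc1-c1cc(Nc2ccc(Br)cc2)nc(N)n1` gives 34 nM, beyond the scatter and lower. For the measured compounds named here, the one single-point step measured, a 4.1-fold higher number from compound 2 to compound 3 (0.61 log units; beyond the scatter), concerns a different swap on an aromatic carbon. Compound 4 `CCOc1ccc(Br)cc1-c1cc(Nc2ccc(Cl)cc2)nc(N)n1` differs from compound 1 by chloro in place of hydroxycarbamoyl on an aromatic carbon. Going by the values given here, no measured step covers this change; the nearest guide is compound 2, which carries bromo on an aromatic carbon and gives 34 nM, the lowest number of the set. Compound 4 is therefore expected to give a lower number than compound 1, by a 2.0-fold lower number from compound 1 to compound 4 (0.29 log units; within the scatter), with an estimate of 45 nM between 15 nM and 140 nM.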

Compound 4, half-maximal inhibitory concentration: 16 nM
Estimate against measurement, compound 4: 2.8-fold (0.45 log units) above; measured number inside the range.
By their numbers in this assay, from the lowest: compound 4; then compound 2; then compounds 1 and 3 (each within the scatter of the next).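

In this assay, chloro in place of hydroxycarbamoyl, on an aromatic carbon para to a large group, brings a 5.5-fold lower number from compound 1 to compound 4 (0.74 log units; beyond the scatter) on the core of compound 1. At this position, then, hydroxycarbamoyl is not required for a low number, and the single chlorine atom gives the stronger inhibition of the pair. Nothing at hand accounts for this step. Going by these compounds, whether a carboxylic acid, an amine or a methoxy group at this position would also give a lower number than hydroxycarbamoyl remains open, as does whether the step holds on the core of compound 2.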